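A few compounds are considered here, and "the series" means these few. Any claim that something is new, unique, unknown or untested is made for them only; others in the source may bear on it.

Measured compounds:
compound 1, `CCOC(=O)c1c(-c2c(Cl)c3ccccc3oc2=O)nn(-c2ccccc2)c1C(=O)OCC`: 100000 nM
compound 2, `CCOC(=O)c1c(-c2c(Cl)c3ccccc3oc2=O)nn(-c2cccc(C)c2)c1C(=O)OCC`: 30000 nM
compound 3, `CCOC(=O)c1c(-c2cc3ccc(OC)cc3oc2=O)nn(-c2ccccc2)c1C(=O)OCC`: 140000 nM

All three were tested in a functional assay on HeLa cells (Homo sapiens) for cytotoxicity, read by MTT assay, with a stated time of 48 h; on this read-out higher numbers stand for weaker inhibition and lower numbers for stronger inhibition. The change from compound 1 to compound 2 is methyl in place of hydrogen on an aromatic carbon, and it made a 3.3-fold lower number from compound 1 to compound 2 (0.52 log units; beyond the scatter). Compound 3 carries a different core; how its core differs from that of compound 1 is not broken down here. In this assay the numbers of compound 1 and compound 3 lie within the scatter of each other, so nothing separates them.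

Compound 4, `CCOC(=O)c1c(-c2cc3ccc(OC)cc3oc2=O)nn(-c2cccc(C)c2)c1C(=O)OCC`, has not yet been measured. It differs from compound 3 by methyl in place of hydrogen on an aromatic carbon, the same change as from compound 1 to compound 2, made at the same place, but on the core of compound 3. Whether the change behaves alike on this other core is not shown by any measured pair, so the expectation rests on one example. Among the compounds with values here, a step of about the same size is expected, that is a 3.1-fold lower number from compound 3 to compound 4 (0.49 log units; beyond the scatter), because a 3.3-fold lower number from compound 1 to compound 2 (0.52 log units; beyond the scatter) is the only comparable example. Compound 4 is therefore estimated at 45000 nM in this assay, with an expected range from 18000 nM to 120000 nM.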

Compound 4, half-maximal inhibitory concentration: 35000 nM
Compound 4: middle estimate off by 1.3-fold (0.11 log units), on the high side; low and high end bracket the measured number.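

In this assay, going from phenyl to 3-methylphenyl on the core of compound 3 gave a 4.0-fold lower number from compound 3 to compound 4 (0.60 log units; beyond the scatter) and so repeated what the same change did on the core of compound 1. The two steps match in size, which means that in this series the change carried over from one core to the other: the same change on two cores in this assay, a 3.3-fold lower number (0.52 log units; beyond the scatter) from compound 1 to compound 2 and a 4.0-fold lower number (0.60 log units; beyond the scatter) from compound 3 to compound 4, 1.2-fold (0.08 log units) apart, within the scatter of two such steps. Within the data shown here, this rests on only two cores and a single position, so it shows that the step held in these two cases, but not that it would hold on any further core, and it does not explain why the methyl lowers the number.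

The compounds shown leave open whether another group in place of this methyl, such as an amine or a longer chain, would give a larger or a smaller step. They also leave open what would happen if the two ethyl ester groups shared by all four compounds gave way to a carboxylic acid.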